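Fluoro for chloro on compound 3

This account rests on a few compounds, and the source may have more. Where it says the series, first, only, none or still open, it means among the compounds named here.

Measured in a functional assay on DU-145 cells (Homo sapiens) for inhibition, read by trypan blue exclusion, with a stated time of 96 h; on this read-out lower numbers stand for stronger inhibition of growth and higher numbers for weaker inhibition of growth:
- compound 1 `COc1ccc(/C=C(\C(=O)c2ccc(Br)cc2)S(=O)(=O)c2ccc(Br)cc2)cc1` gives 25000 nM
- compound 2 `O=C(/C(=C\c1ccc(Br)c(O)c1)S(=O)(=O)c1ccc(Br)cc1)c1ccc(Br)cc1` gives 50000 nM
- compound 3 `O=C(/C(=C\c1ccc(Cl)cc1Cl)S(=O)(=O)c1ccc(Br)cc1)c1ccc(Br)cc1` gives 10000 nM

Compound 3 has the lowest of these numbers, beyond the scatter of both others. Compound 4 `O=C(/C(=C\c1ccc(F)cc1Cl)S(=O)(=O)c1ccc(Br)cc1)c1ccc(Br)cc1` departs from it by one change, fluoro in place of chloro on an aromatic carbon. Among the compounds with values here, no measured step makes this exchange. The nearest evidence replaces the whole substituted phenyl group: a 2.5-fold lower number from compound 1 to compound 3 (0.40 log units; beyond the scatter), and a 5.0-fold lower number from compound 2 to compound 3 (0.70 log units; beyond the scatter), both modest, while a 2.0-fold higher number from compound 1 to compound 2 (0.30 log units; within the scatter). A single halogen exchange is therefore expected to move this assay by less, with no clear direction and nothing beyond the scatter. The estimated step is a 1.2-fold higher number from compound 3 to compound 4 (0.08 log units; within the scatter). Compound 4 is expected at about 12000 nM, within an estimated range of 5000 nM to 30000 nM.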

Compound 4, concentration for 50% growth inhibition: 50000 nM
Estimate against measurement, compound 4: 4.2-fold (0.62 log units) below; the whole stated range lies below it.
By their numbers in this assay, from the lowest: compound 3; then compounds 1, 2 and 4 (each within the scatter of the next).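

In this assay, within the data shown here, this one position proves sensitive to a single halogen exchange (a 5.0-fold higher number from compound 3 to compound 4 (0.70 log units; beyond the scatter)), a step as large as the widest whole-group exchange among the earlier compounds (a 5.0-fold lower number from compound 2 to compound 3 (0.70 log units; beyond the scatter)). The advantage of the 2,4-dichlorophenyl group goes with that one atom, since 2-chloro-4-fluorophenyl stands level with both other groups (no change at the digits printed from compound 2 to compound 4 (within the scatter); a 2.0-fold higher number from compound 1 to compound 4 (0.30 log units; within the scatter)). Nothing available explains the loss.

The compounds shown leave open whether chloro is special at this place, or whether bromo, methyl or an amine there would keep the lower number of compound 3.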